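A few compounds are considered here, and "the series" means these few. Any claim that something is new, unique, unknown or untested is made for them only; others in the source may bear on it.

Of the compounds shown here, two have been tested in a functional assay on HepG2 cells (Homo sapiens) for antiproliferative activity, read by MTT assay, with a stated time of 48 h; on this read-out lower numbers stand for stronger inhibition and higher numbers for weaker inhibition. Compound 1 `N#CC1=C(N)Oc2c(c3nc4ccccc4nc3c3ccccc23)C12C(=O)N(Cc1cnnn1-c1ccc(S(N)(=O)=O)cc1)c1ccccc12` gives 42200 nM in this assay, a weak effect on the cells. Compound 2 `Cc1ccccc1-n1nncc1CN1C(=O)C2(C(C#N)=C(N)Oc3c(N)cc4nc5ccccc5nc4c32)c2ccccc21` is recorded in this assay only as a limit, > 50000 nM, which means no actual number was reached for it. Among the measured compounds shown here, its place is therefore set by the limit of > 50000 nM in this assay, at which 1 of the 2 values shown sits, at the top of the range the assay reports, with compound 1 the only compound showing a real number, and that number itself a high one.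

Compound 3 `Cc1cccc(-n2nncc2CN2C(=O)C3(C(C#N)=C(N)Oc4c(N)cc5nc6ccccc6nc5c43)c3ccccc32)c1` is the next compound in line. It differs from compound 2 by a single rearrangement: 3-methylphenyl in place of 2-methylphenyl on an aromatic nitrogen. No change between two measured compounds is available to show what such a shift does here, so the expectation rests on how close compound 3 stays to compound 2. Moving the methyl from one position to another on the same ring is expected to produce a step from compound 2 to compound 3 of a number no higher from compound 2 to compound 3 (the limit leaves the size open), that is, no move beyond the usual scatter. Compound 3 is accordingly estimated at 50000 nM in this assay, within a range from 25000 nM to 100000 nM, with a fair chance that only a limit is reported again.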

Compound 3, half-maximal inhibitory concentration: > 50000 nM
Compound 3: a limit, no number; the forecaster's own chance of this, stated with the estimate: 60%; the middle value lies on the limit itself.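

Among the compounds shown here, compound 2 and compound 3 both stand in this assay as limits and not as numbers, and no step between them can be read. The compounds shown leave open whether 3-methylphenyl in place of 2-methylphenyl changes the effect on the cells at all, and the values now gather at one point: the limit of > 50000 nM in this assay, at which 2 of the 3 values shown sit.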